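The compounds below may be only part of what the source reports. "The series", "measured", "known", "first", "only" and "open" are said of these compounds alone.

Compound 1 `COc1cc(C(=O)/C=C/c2cc(OC)c(OC)cc2OC)ccc1O` gives > 150000 nM in a functional assay on HeLa cells (Homo sapiens) for inhibition, read by MTT assay, with a stated time of 72 h (on this read-out lower numbers stand for stronger inhibition and higher numbers for weaker inhibition), which is a limit of the assay.
Compound 2 `COc1cc(OC)c(OC)cc1/C=C/C(=O)c1ccc([N+](=O)[O-])cc1` gives > 150000 nM in this assay, again a limit.
Compound 3 `COc1cc(OC)c(OC)cc1/C=C/C(=O)c1ccc(-c2c[nH]cn2)cc1` gives > 150000 nM in this assay, also a limit.

All three measured compounds share the same core and all sit at the limit of > 150000 nM in this assay, at which 3 of the 3 values shown sit. Among the compounds with values here, compound 3 therefore stands at that limit, not at a number, and no measured compound shows anything stronger. Within the data shown here, the one step between structures that differ in a single place, a step that the two limits leave unreadable from compound 2 to compound 3, runs from one limit to another and so says nothing about size or direction.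

Compound 4 `COc1cc(OC)c(OC)cc1/C=C/C(=O)c1ccc(Cl)cc1` differs from compound 3 in one place: chloro in place of 1H-imidazol-4-yl on an aromatic carbon. Among the measured compounds shown here, no measured step bears on this exchange in a readable way, and with every measured value at the limit there is no basis for expecting a move beyond the scatter in this assay. For compound 4 the step that the limit leaves unreadable from compound 3 to compound 4 is therefore expected to be essentially none. Compound 4 is estimated at 200000 nM, within 50000 nM to 800000 nM, most likely reported again only as a limit.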

Compound 4, half-maximal inhibitory concentration: 36500 nM
For compound 4 the middle estimate is 5.5-fold (0.74 log units) above the measured one; the measured number lies below the stated range.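

Within the data shown here, compound 4 is the first compound here to give a number rather than a limit in this assay, which shows that this position, para to a large group, can change the read-out. Chloro in place of 1H-imidazol-4-yl gives an at least 4.1-fold lower number from compound 3 to compound 4 (0.61 log units; beyond the scatter), and chloro in place of nitro gives an at least 4.1-fold lower number from compound 2 to compound 4 (0.61 log units; beyond the scatter), so both exchanges point towards stronger inhibition. Each of these sizes is only a minimum, since the other end of each step is a limit and not a number: the limit of > 150000 nM in this assay, at which 3 of the 4 values shown sit.

On these data alone, whether this shift belongs to chloro alone, or would also appear with bromo, methyl or an amine in the same place, stays open. As far as these compounds go, the true size of both steps also stays open, as does whether a change elsewhere on the shared core would move the number further.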